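The source may hold more compounds than are shown below. What is called first, only, known or untested is meant among the compounds shown, and "the series" means these compounds.

Working notes on the series.

Three members of the series have been run through an ADME assay on Huh7.5.1 cells (Homo sapiens) for cytotoxicity, read by ATP content, with a stated time of 48 h; a higher number here means that more compound is tolerated, a lower number that less compound is tolerated. Compound 1 `Cc1oc(-c2c(Cl)cccc2Cl)nc1CN1CCC(C(=O)NCCCN2C[C@H](C)C[C@H](C)C2)CC1` gives 13200 nM in this assay, the highest of the three numbers. Compound 3 `Cc1cccc(Cl)c1-c1nc(CN2CCC(C(=O)NCCCN3CCC(C)(C)CC3)CC2)c(C)o1` gives 11700 nM, which sits within the scatter of compound 1, so no order between the two can be read. Compound 2 `Cc1ccccc1-c1nc(CN2CCC(C(=O)NCCCN3CCCC(CC(C)C)C3)CC2)c(C)o1` gives 4640 nM, the lowest of the three and beyond the scatter from compound 1; compound 2 differs from compound 1 in more than one place, so no single change can be tied to that gap.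

Compound 4 `COc1cccc(F)c1-c1nc(CN2CCC(C(=O)NCCCN3C[C@H](C)C[C@H](C)C3)CC2)c(C)o1` has not yet been measured in this assay. It differs from compound 1 in one place: 2-fluoro-6-methoxyphenyl in place of 2,6-dichlorophenyl on an aromatic carbon. Among the measured compounds shown here, no measured pair isolates a change of this kind, so the size of the step is open. Given that compound 1 and compound 3 sit together despite differing in their aryl group, a step of the same order is expected from compound 1 to compound 4, a 1.2-fold lower number from compound 1 to compound 4 (0.08 log units; within the scatter), with no direction beyond the scatter asserted. Compound 4 is therefore estimated at 11000 nM in this assay, with a range from 5000 nM to 25000 nM.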

Compound 4, half-maximal cytotoxic concentration: 37000 nM
For compound 4 the middle estimate is 3.4-fold (0.53 log units) below the measured one, outside the stated range (above it).
By their numbers in this assay, from the lowest: compound 2; then compounds 3 and 1 (each within the scatter of the next); then compound 4.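

Among the compounds shown here, this aromatic carbon of the shared core is not silent in this assay: 2-fluoro-6-methoxyphenyl in place of 2,6-dichlorophenyl gives a 2.8-fold higher number from compound 1 to compound 4 (0.45 log units; beyond the scatter) with the rest of the structure held fixed, the first single-place step. The entering group carries 1 hydrogen-bond acceptor and the leaving group none, but the fluorine and the methoxy enter together, so this step cannot be divided between them. Nothing at hand gives a reason for the step.

As far as these compounds go, it remains open how a 2,6-difluorophenyl or a 2,6-dimethoxyphenyl group on this carbon would read in this assay, which would separate the two substituents. From the compounds shown here alone, it is also open whether the step carries over to compounds with a different group at the far end of the chain.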